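Removing One Methoxy Group From a Growth-Inhibiting Scaffold

This account rests on a few compounds, and the source may have more. Where it says the series, first, only, none or still open, it means among the compounds named here.

Measured compounds:
- compound 1, `COc1cc2c(c(OC)c1)OCN(c1ccc3oc(-c4ccccc4)cc(=O)c3c1)C2`: 79%
- compound 2, `Cc1cc(C)c2c(c1)CN(c1ccc3c(=O)cc(-c4ccccc4)oc3c1)CO2`: 26.8%
- compound 3, `O=c1cc(-c2ccccc2)oc2cc(N3COc4c(Br)cc(Br)cc4C3)ccc12`: 11.1%

Three compounds share a core and differ only in the groups attached to one ring. In a functional assay on MCF7 cells (Homo sapiens) for inhibition, read by MTT assay, with a stated time of 48 h, tested at 30 ug/mL (a higher number here means more inhibition of growth at the concentration tested, a lower number less inhibition of growth), compound 1 gives 79%, the highest of the three values. Compound 2 gives 26.8% in this assay, a value far lower than that of compound 1, beyond the usual scatter. Compound 3 gives 11.1% in this assay, lower still, again beyond the scatter. The compound carrying methoxy groups thus stands clearly above the ones carrying methyl or bromo groups.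

Compound 4, `COc1cccc2c1OCN(c1ccc3oc(-c4ccccc4)cc(=O)c3c1)C2`, has not yet been measured. It differs from compound 1 in one place: hydrogen in place of methoxy on an aromatic carbon. The change sits on an aromatic carbon of a six-membered aromatic ring of carbon only, part of a fused system of two rings, meta to a fused ring and meta to a methoxy group.

For the measured compounds named here, no directly comparable step between measured compounds exists, so the expectation rests on the values alone. Because compound 1 gives 79% while the compounds without methoxy groups give much less, the loss of a methoxy group is expected to lower inhibition, though a single methoxy group remains. The step from compound 1 to compound 4 is estimated at a number 24 percentage points lower from compound 1 to compound 4 (beyond the scatter), a decrease beyond the scatter. Compound 4 is therefore expected to give about 55% in this assay, within a range of 30% to 78%.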

Compound 4, percent growth inhibition at one concentration: 67.8%
For compound 4 the middle estimate is 12.8 percentage points below the measured one; the range from low to high includes it.
By their numbers in this assay, from the lowest: compound 3; then compound 2; then compound 4; then compound 1.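

For the compounds shown here, compound 1 and compound 4 differ in one place, so this pair is the first to show what a single methoxy group contributes on its own. In this assay hydrogen in place of methoxy on this aromatic carbon brings a modest but real loss (a number 11.2 percentage points lower from compound 1 to compound 4 (beyond the scatter)), and with one methoxy group remaining, compound 4 still gives 67.8% of growth inhibition, so this position tolerates losing its methoxy group without the activity collapsing. Nothing measured here explains the size of this step.

The compounds shown leave open whether an amine or a longer chain, such as ethoxy, on this carbon would give more or less inhibition than methoxy. They also leave open how the number would move with hydrogen in place of the remaining methoxy group.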